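Methoxy in Place of Hydrogen on the Aromatic Ring

The source may report more compounds than this note shows. Statements on the series, on what has been measured and on what is new or still open speak of the compounds shown alone.

Three compounds have been measured in a toxicity assay on the whole organism (strain Icem-CET (SPF Caw)) for cytotoxicity, with Mus musculus as the target; a higher number here means that more compound is needed for the effect, a lower number that less compound is needed:

compound 1, `C/C(C(=O)NC1CC1)=C(/C)c1ccc(F)cc1`, gives 200 mg/kg
compound 2, `C=CCNC(=O)/C(C)=C(\C)c1ccc(OC)cc1`, gives 300 mg/kg
compound 3, `C/C(C(=O)NC1CC1)=C(/C)c1ccccc1`, gives 250 mg/kg

Compound 3 has the second highest of these three numbers. Its nearest neighbour is compound 2 and its furthest is compound 1, yet both gaps lie within the usual scatter of this assay, so the three compounds cannot be told apart by these numbers. Among the compounds with values here, the only step between two compounds that differ in a single place is a 1.3-fold higher number from compound 1 to compound 3 (0.10 log units; within the scatter), that is, hydrogen in place of fluoro on the aromatic carbon.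

Compound 4, `COc1ccc(/C(C)=C(\C)C(=O)NC2CC2)cc1`, is not yet measured. It differs from compound 3 by methoxy in place of hydrogen on an aromatic carbon. The step from compound 1 to compound 3 bears on this change, since it also swaps a group on that same aromatic carbon, and it stayed within the scatter. Within the data shown here, compound 2 carries a methoxy too, but it also differs from compound 3 in the group on the amide nitrogen, so it shows only that a methoxy-bearing compound can give a number close to that of compound 3.

Compound 4 is therefore expected to change by a 1.1-fold higher number from compound 3 to compound 4 (0.03 log units; within the scatter), no step beyond the scatter. The estimate for compound 4 in this assay is 270 mg/kg, with a range from 170 mg/kg to 430 mg/kg.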

Compound 4, dose for half-maximal effect: 300 mg/kg
Beside the measured number, compound 4's estimate is 1.1-fold (0.05 log units) below it, and the stated range covers the measured number.
By their numbers in this assay, from the lowest: compounds 1, 3, 2 and 4 (each within the scatter of the next).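

On the aromatic carbon para to a large group, methoxy in place of hydrogen gives a 1.2-fold higher number from compound 3 to compound 4 (0.08 log units; within the scatter) in this assay, and methoxy in place of fluoro gives a 1.5-fold higher number from compound 1 to compound 4 (0.18 log units; within the scatter), so hydrogen, fluoro and methoxy at this position, each with cyclopropyl on the amide nitrogen, cannot be told apart by these numbers. The earlier compounds shown here left methoxy tied to an allyl group on the nitrogen, whereas compound 4 isolates that nitrogen group: with methoxy held constant, cyclopropyl in place of allyl gives no change at the digits printed from compound 2 to compound 4 (within the scatter), so this swap also leaves no readable difference. No independent measurement is available to explain why these numbers stay so close together.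

As far as these compounds go, what remains open is whether a group of a different kind on this aromatic carbon, such as an amine or a carboxylic acid, would move the number beyond the scatter. The same question stands for a longer chain on the amide nitrogen, since the two groups compared there, allyl and cyclopropyl, are the only ones shown.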